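The source may report more compounds than this note shows. Statements on the series, on what has been measured and on what is new or still open speak of the compounds shown alone.

Compound 1 `Cc1ccccc1-c1nn(-c2ccc(F)cc2F)cc1CNCCN1CCCCC1` gives > 20000 nM in an ADME assay on Huh-7 cells (Homo sapiens) for cytotoxicity (a lower number here means that less compound is tolerated, a higher number that more compound is tolerated), which is a limit of the assay and not a number.
Compound 2 `Cc1ccccc1-c1nn(-c2ccc(F)cc2F)cc1CNCCN1CCN(C)CC1` gives > 20000 nM in this assay, again a limit of the assay.
Compound 3 `Cc1ccccc1-c1nn(-c2ccc(F)cc2F)cc1CNCCN(C)C` gives > 20000 nM in this assay, also a limit of the assay.

Compound 3 therefore stands where its two companions stand: at the limit of > 20000 nM in this assay, at which 3 of the 3 values shown sit. The three steps among the measured compounds are unreadable: a step that the two limits leave unreadable from compound 1 to compound 2, a step that the two limits leave unreadable from compound 1 to compound 3 and a step that the two limits leave unreadable from compound 2 to compound 3 each join two limits, so neither their size nor their direction can be read.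

The step to the unmeasured compound 4 `Cc1ccccc1-c1nn(-c2ccc(F)cc2F)cc1CN1CCN(C(C)C)CC1` is 4-isopropylpiperazin-1-yl in place of (2-(dimethylamino)ethyl)amino on a saturated chain carbon bound to an aromatic carbon. The measured steps bear on it only loosely, since all three exchange the outer amine of the side chain and leave the rest of the molecule untouched, and none of them produced a readable change in this assay. No step beyond the scatter is therefore expected in this assay from compound 3 to compound 4, and the expected step that the limit leaves unreadable from compound 3 to compound 4 reflects that. Compound 4 is estimated at 30000 nM, with a range from 10000 nM to 100000 nM, most likely reported again as a limit.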

Compound 4, half-maximal cytotoxic concentration: > 20000 nM
Compound 4 was reported as a limit; the forecaster's own chance of this, stated with the estimate: 85%; the middle value lies beyond the limit too.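

The steps from compound 1, compound 2 and compound 3 to compound 4 each join two limits of the assay, so none can be read in size or direction: the limit of > 20000 nM in this assay, at which 4 of the 4 values shown sit.

The compounds shown leave open at what concentration any of them harms the cells in this assay, and whether exchanging the side chain changes that concentration.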